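A few compounds are considered here, and "the series" means these few. Any claim that something is new, unique, unknown or untested is made for them only; others in the source may bear on it.

Working notes on the series. The four compounds share one core and differ only in the group on its aromatic carbon. Compound 1 `NC(=O)c1cn([C@@H]2O[C@H](CO)[C@@H](O)[C@H]2O)nn1` carries carbamoyl; in a functional assay on L1210 cells (Mus musculus) (on this read-out higher numbers stand for weaker inhibition and lower numbers for stronger inhibition), compound 1 gives only a limit, > 200000 nM. Compound 2 `CCCCCCc1cn([C@@H]2O[C@H](CO)[C@@H](O)[C@H]2O)nn1` carries hexyl; in this assay compound 2 likewise gives a limit, > 200000 nM. Between them lies a step that the two limits leave unreadable from compound 1 to compound 2. Among the compounds with values here, compound 3 `CCCCCCCCc1cn([C@@H]2O[C@H](CO)[C@@H](O)[C@H]2O)nn1` carries octyl, and in this assay compound 3 gives 56000 nM, the only number among the three values shown. The step is an at least 3.5-fold lower number from compound 2 to compound 3 (0.55 log units; beyond the scatter).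

Compound 4 `OCc1cn([C@@H]2O[C@H](CO)[C@@H](O)[C@H]2O)nn1` differs from compound 3 by hydroxy in place of heptyl on a saturated chain carbon bound to an aromatic carbon. Two observations bear on it. Chain length matters in the measured direction: lengthening the chain gave an at least 3.5-fold lower number from compound 2 to compound 3 (0.55 log units; beyond the scatter), so removing heptyl should move the number back up. The carbamoyl group of compound 1 sits at the limit of > 200000 nM in this assay, at which 2 of the 3 values shown sit. Compound 4 is therefore expected to rise beyond the scatter, most likely to a limit again, a 7.1-fold higher number from compound 3 to compound 4 (0.85 log units; beyond the scatter). The estimate for compound 4 is 400000 nM, within 120000 nM to 3000000 nM.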

Compound 4, half-maximal inhibitory concentration: > 200000 nM
Compound 4 ended at the assay's limit; the forecaster's own chance of this, stated with the estimate: 85%; the middle value is on the limit's open side.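

Hydroxy in place of heptyl on a saturated chain carbon bound to an aromatic carbon gives an at least 3.5-fold higher number from compound 3 to compound 4 (0.55 log units; beyond the scatter) in this assay, so the one readable number in the series does not survive this shortening. Compound 4 gives only a limit of the assay, and its steps from compound 1 and from compound 2 cannot be read. Only octyl now stands clear of that limit, and a small hydroxymethyl group does no better than carbamoyl or hexyl can be shown to do: the limit of > 200000 nM in this assay, at which 3 of the 4 values shown sit.

As far as these compounds go, how far compound 1, compound 2 and compound 4 lie beyond the limit stays open, so carbamoyl, hexyl and hydroxymethyl cannot be ranked against one another. Also open, from the compounds shown here alone, is whether a longer chain such as decyl or dodecyl, or an octyl chain ending in an amine or a carboxylic acid, would give a lower number than octyl.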